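This account rests on a few compounds, and the source may have more. Where it says the series, first, only, none or still open, it means among the compounds named here.

Compound 2, `CCn1nc2oc(=O)cc(C)c2c1C`, was measured in a functional assay on the whole organism with Mus musculus as the target, in the writhing test (on this read-out lower numbers stand for an effect already at smaller amounts and higher numbers for an effect only at larger amounts of compound), and gives 14.6 mg/kg. Compound 1, `CCCn1nc2oc(=O)cc(C)c2c1C`, in this assay gives 72.6 mg/kg. Of these two numbers, compound 2 has the lower one; the step of a 5.0-fold lower number from compound 1 to compound 2 (0.70 log units; beyond the scatter) separates them. Compound 3, `Cc1cc(=O)oc2nn(C(C)C)c(C)c12`, has not yet been measured. The change from compound 2 to compound 3 is methyl in place of hydrogen on a saturated chain carbon bound to an aromatic nitrogen and a saturated chain carbon. Going by the values given here, one measured step bears on this change: the step of a 5.0-fold lower number from compound 1 to compound 2 (0.70 log units; beyond the scatter) removed a methyl from the chain on the same nitrogen, and this assay answered with a clearly lower number. Among the compounds with values here, the change to compound 3 puts a methyl back onto that chain, though at a different carbon, so a move back toward a higher number is expected, likely smaller than the measured step; the chain differs in where the methyl sits, and no measured compound shows this arrangement. For compound 3, the estimated value in this assay is 30 mg/kg, with a range from 12 mg/kg to 80 mg/kg, which would mean an expected step of a 2.1-fold higher number from compound 2 to compound 3 (0.31 log units; beyond the scatter).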

Compound 3, dose for half-maximal effect: 35.3 mg/kg
Beside the measured number, compound 3's estimate is 1.2-fold (0.07 log units) below it; low and high end bracket the measured number.
By their numbers in this assay, from the lowest: compound 2; then compound 3; then compound 1.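

In this assay, a methyl added to the ethyl on the aromatic nitrogen also raises the number when it sits on the saturated chain carbon bound to that nitrogen: the change to isopropyl gives a 2.4-fold higher number from compound 2 to compound 3 (0.38 log units; beyond the scatter) as its step. Isopropyl in place of propyl gives a 2.1-fold lower number from compound 1 to compound 3 (0.31 log units; beyond the scatter) as its step, so the place of the methyl on the chain matters, and not only its presence. Of the three groups tried on this nitrogen, ethyl gives the lowest number, but nothing shown explains the order.

From the compounds shown here alone, whether a plain methyl on this nitrogen would go lower still remains open. So does how a cyclopropyl ring, a longer chain such as butyl, or a chain ending in a hydroxyl group would compare with ethyl.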